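Series notes: aryl change on the core nitrogen

The source may report more compounds than this note shows. Statements on the series, on what has been measured and on what is new or still open speak of the compounds shown alone.

The shared core is set by compound 1 `CNC(=O)c1cc(Oc2ccc(NC(=O)c3cc4cccnc4n(-c4ccc(F)cc4)c3=O)cc2)ccn1`, which in a functional assay on U-87MG ATCC cells for antiproliferative activity against U-87 MG (Homo sapiens), read by MTT assay, with a stated time of 72 h (on this read-out lower numbers stand for stronger inhibition and higher numbers for weaker inhibition), gives 2910 nM. Compound 2 `CNC(=O)c1cc(Oc2ccc(NC(=O)c3cc4cccnc4n(-c4ccc(Cl)cc4)c3=O)cc2)ccn1` carries 4-chlorophenyl in the same position, but in this assay compound 2 is recorded as "not determined" (no result reported), so it stands without a number on this read-out and its place against compound 1 cannot be stated. Compound 3 `CNC(=O)c1cc(Oc2ccc(NC(=O)c3cc4cccnc4n(-c4ccc(C(F)(F)F)cc4Cl)c3=O)cc2)ccn1` is the next member awaiting measurement. The change from compound 2 to compound 3 is 2-chloro-4-(trifluoromethyl)phenyl in place of 4-chlorophenyl on an aromatic nitrogen. Among the compounds with values here, no step between two measured compounds is available, so the size and direction of this step can only be guessed. The working expectation is a modest gain that may stay within the usual scatter, anchored on compound 1 at 2910 nM. Compound 3 is therefore estimated at 1500 nM, with a range from 400 nM to 6000 nM.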

Compound 3, half-maximal inhibitory concentration: 19800 nM
Beside the measured number, compound 3's estimate is 13-fold (1.12 log units) below it; measured number outside the range, above it.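

The aryl group on the aromatic nitrogen now gives its first readable step in this assay: 2-chloro-4-(trifluoromethyl)phenyl in place of 4-fluorophenyl gives a 6.8-fold higher number from compound 1 to compound 3 (0.83 log units; beyond the scatter), a move toward weaker inhibition. The number at this position therefore depends on the aryl group, at least across these two compounds. Nothing on hand speaks to the cause of this rise.

The step from compound 2 to compound 3 cannot be read, as compound 2 has no number in this assay, and the compounds shown do not separate the contribution of the 2-chloro group from that of the trifluoromethyl group. Also open, going by these compounds, is how this position would read with an unsubstituted phenyl, or with a methoxy group or an amine on the aryl ring.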